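The compounds below may be only part of what the source reports. "The series", "measured", "known", "first", "only" and "open" are said of these compounds alone.

Working notes on the sulfonamide series.

Three compounds have numbers in a functional assay on B16-F10 cells (Mus musculus) for antiproliferative activity, read by MTT assay, with a stated time of 48 h; on this read-out lower numbers stand for stronger inhibition and higher numbers for weaker inhibition. Compound 1 `Cc1ncc([N+](=O)[O-])n1CC(=O)NS(=O)(=O)c1ccc(Br)cc1` gives 2.37 ug/mL. Compound 2 `Cc1ccc(S(=O)(=O)NC(=O)Cc2ccc(F)cc2)cc1` gives 9.94 ug/mL, and compound 3 `O=C(Cc1ccc(F)cc1)NS(=O)(=O)c1ccc(F)cc1` gives 4.23 ug/mL. Within this set compound 1 carries the lowest number, but its gap to compound 3 lies within the scatter, so the two cannot be ordered; only the gap to compound 2 stands beyond it.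

One single-point step is available: a 2.3-fold lower number from compound 2 to compound 3 (0.37 log units; beyond the scatter). Here a halogen replaced a methyl on the ring attached to the sulfonyl group and the number fell.

Compound 4 `Cc1ncc([N+](=O)[O-])n1CC(=O)NS(=O)(=O)c1ccccc1` is not yet measured. Its change from compound 1 is hydrogen in place of bromo on an aromatic carbon, on an aromatic carbon of a six-membered aromatic ring of carbon only, the ring carrying the sulfonyl group. Among the measured compounds shown here, the one step that bears on it ran the other way, toward a halogen, and was modest. Removing the halogen is therefore expected to raise the number somewhat, by a 1.7-fold higher number from compound 1 to compound 4 (0.23 log units; within the scatter), a step that may not clear the scatter. The estimate for compound 4 in this assay is 4 ug/mL, with a range from 2 ug/mL to 8 ug/mL.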

Compound 4, half-maximal inhibitory concentration: 2.93 ug/mL
Compound 4: the middle estimate sits 1.4-fold (0.14 log units) above what was measured, and the stated range covers the measured number.
By their numbers in this assay, from the lowest: compounds 1, 4 and 3 (each within the scatter of the next); then compound 2.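

In this assay the move to hydrogen gives a 1.2-fold higher number from compound 1 to compound 4 (0.09 log units; within the scatter) and so, on the core of compound 1, bromo and hydrogen on this aromatic carbon, para to a large group, cannot be told apart. Among the compounds shown here, the only earlier step at this ring, a 2.3-fold lower number from compound 2 to compound 3 (0.37 log units; beyond the scatter) for fluoro in place of methyl on a different core, lay beyond the scatter, whereas taking 4-bromophenyl to phenyl here produces no change that this read-out can resolve, so that earlier step does not carry over to this pair. Nothing at hand bears on why this step is so small.

The compounds shown leave open whether a group other than bromo or hydrogen on this carbon, such as an amine, a carboxylic acid or a methoxy group, would move the number beyond the scatter on this core. They also leave open whether fluoro and methyl, the groups that separate compound 3 from compound 2, would differ on the core of compound 1 as they do on their own.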